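A Methoxy Group Changes Place in Compound 3

The compounds below may be only part of what the source reports. "The series", "measured", "known", "first", "only" and "open" are said of these compounds alone.

In an ADME assay on HepG2 cells (Homo sapiens) for cytotoxicity, read by MTT assay, with a stated time of 72 h (on this read-out higher numbers stand for lower toxicity in this test and lower numbers for higher toxicity in this test), compound 1 `O=[N+]([O-])c1c(CS(=O)(=O)c2ccccc2)nc2c(C#Cc3ccccc3)cc(Cl)cn12` gives > 3900 nM, which is a limit of the assay and not a number. Compound 2 `COc1cccc(C#Cc2cc(Cl)cn3c([N+](=O)[O-])c(CS(=O)(=O)c4ccccc4)nc23)c1` gives > 3900 nM, which is also only a limit. Going by the values given here, compound 2 therefore has no exact position on the scale, and neither does the one other compound measured so far.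

Compound 3 `COc1ccccc1C#Cc1cc(Cl)cn2c([N+](=O)[O-])c(CS(=O)(=O)c3ccccc3)nc12` has the same atoms as compound 2, joined differently: 2-methoxyphenyl in place of 3-methoxyphenyl on a triple-bonded carbon. In words, 2-methoxyphenyl stands in place of 3-methoxyphenyl on a triple-bonded carbon.

Among the compounds with values here, only one measured step bears on this change, the addition of methoxy in place of hydrogen on an aromatic carbon. It is a step that the two limits leave unreadable from compound 1 to compound 2, so it offers no size to carry over. The evidence is thin: the limit of > 3900 nM in this assay, at which 2 of the 2 values shown sit. No step beyond the usual scatter can be predicted in either direction, and another limit is the most likely report.

The expected change in this assay is a step that the limit leaves unreadable from compound 2 to compound 3. For compound 3 the estimated value is 5000 nM, with an expected range from 2500 nM to 12000 nM.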

Compound 3, half-maximal cytotoxic concentration: > 3900 nM
Compound 3: a limit, no number; the forecaster's own chance of this, stated with the estimate: 80%; the middle value is on the limit's open side.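

In this assay compound 3 gives > 3900 nM, a limit of the assay and not a number. No step can be read among compound 1, compound 2 and compound 3, because all three stop at a limit: the limit of > 3900 nM in this assay, at which 3 of the 3 values shown sit. The compounds shown leave open whether adding the methoxy group or changing its place alters the reading at all.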